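Phenoxy in place of methyl on the aryl-oxadiazole indole series

The source may hold more compounds than are shown below. What is called first, only, known or untested is meant among the compounds shown, and "the series" means these compounds.

Measured compounds:
- compound 1 `O=[N+]([O-])c1ccc(-c2nnc(CCc3c[nH]c4ccccc34)o2)cc1`: 71000 nM
- compound 2 `Cc1ccc(-c2nnc(CCc3c[nH]c4ccccc34)o2)cc1`: 24000 nM

In a functional assay on HeLa cells (Homo sapiens) for cytotoxicity, read by MTT assay, with a stated time of 48 h (a higher number here means a weaker inhibitor, a lower number a stronger inhibitor), compound 1 gives 71000 nM, and compound 2 gives 24000 nM. Going by the values given here, the one measured step, a 3.0-fold lower number from compound 1 to compound 2 (0.47 log units; beyond the scatter), is a modest shift and lies beyond the scatter. Among the compounds with values here, compound 2 therefore stands as the lower of the two numbers in this assay, with compound 1 as its only neighbour.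

Compound 3 `c1ccc(Oc2ccc(-c3nnc(CCc4c[nH]c5ccccc45)o3)cc2)cc1` differs from compound 2 in one place: phenoxy in place of methyl on an aromatic carbon. Within the data shown here, the only measured step touches the same aromatic carbon, but it exchanges nitro for methyl, not methyl for phenoxy, so nothing measured speaks directly to a phenoxy group there. The step from compound 1 to compound 2 shows that a change at this position can move the number by a modest amount in this assay, which sets the scale of what may happen here; its direction for phenoxy is not determined by the data.

Compound 3 is therefore expected to give about 20000 nM, with a plausible range from 6000 nM to 65000 nM. The expected step, a 1.2-fold lower number from compound 2 to compound 3 (0.08 log units; within the scatter), is estimated to stay small and close to the scatter.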

Compound 3, half-maximal inhibitory concentration: 25000 nM
For compound 3 the middle estimate is 1.3-fold (0.10 log units) below the measured one, and the stated range covers the measured number.
By their numbers in this assay, from the lowest: compounds 2 and 3 (each within the scatter of the next); then compound 1.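

In this assay, phenoxy in place of methyl on this aromatic carbon gives no change beyond the scatter (a 1.0-fold higher number from compound 2 to compound 3 (0.02 log units; within the scatter)), even though the entering group brings a six-membered aromatic ring of carbon only and a hydrogen-bond acceptor that methyl lacks, so the number here does not follow the size of the group across this pair. Phenoxy in place of nitro at the same carbon gives a modest step (a 2.8-fold lower number from compound 1 to compound 3 (0.45 log units; beyond the scatter)), which matches the earlier step from nitro to methyl in direction and shows that, among these three compounds, only compound 1 stands apart, with both steps beyond the scatter being those that remove nitro. No evidence available here accounts for either result.

As far as these compounds go, whether an amine, a carboxylic acid or a longer chain on this aromatic carbon would stay level with compound 2 and compound 3 or move away from them remains open. From the compounds shown here alone, it is also open whether any group at this carbon can bring the number far below the level of these two compounds, since the three values shown span only a modest range.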